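This account rests on a few compounds, and the source may have more. Where it says the series, first, only, none or still open, it means among the compounds named here.

In a functional assay on Ishikawa cells (Homo sapiens) for antiproliferative activity, read by MTT assay, with a stated time of 24 h (a higher number here means that more compound is needed for the effect, a lower number that less compound is needed), compound 1 `CCOC(=O)CO/N=C(\c1ccc(SC)cc1)c1cccc2ccccc12` is reported only as a limit, > 50000 nM. Going by the values given here, compound 2 `CSc1ccc(/C(=N\OCCCCN2CCCCC2)c2cccc3ccccc23)cc1` gives 18000 nM, the only actual number so far. Among the compounds with values here, the single measured step, an at least 2.7-fold lower number from compound 1 to compound 2 (0.44 log units; beyond the scatter), starts from the limit of > 50000 nM in this assay, at which 1 of the 2 values shown sits, and replaces a different group, so it does not bear directly on ring size. Compound 3 `CSc1ccc(/C(=N\OCCCCN2CCCC2)c2cccc3ccccc23)cc1` differs from compound 2 as follows: pyrrolidin-1-yl in place of piperidin-1-yl on a saturated chain carbon, four bonds along the chain from an oxygen. The change sits four bonds along the chain from an oxygen. Within the data shown here, no measured step covers this swap, so no step beyond the scatter is expected in this assay. The expected change is no change at the digits printed from compound 2 to compound 3 (within the scatter). For compound 3 the estimated value is 18000 nM, within a range of 8000 nM to 40000 nM.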

Compound 3, half-maximal effective concentration: > 50000 nM
Compound 3 gave a limit, no number; the forecaster's own chance of this, stated with the estimate: 8%; at least 2.7-fold (0.44 log units) between middle value and limit.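

In this assay, the ring at the end of the chain now proves to matter, which the earlier step could not show: pyrrolidin-1-yl in place of piperidin-1-yl gives an at least 2.7-fold higher number from compound 2 to compound 3 (0.44 log units; beyond the scatter). On these data alone, compound 3 is reported only as a limit, > 50000 nM, so the size of this loss stays open-ended, and the step between the two limits of compound 1 and compound 3 cannot be read. Compound 2 remains the only compound with an actual number, and the rest share one limit: the limit of > 50000 nM in this assay, at which 2 of the 3 values shown sit.

The compounds shown leave open whether azepan-1-yl, morpholin-4-yl or an open-chain diethylamino group on the same chain would keep or lower the number of compound 2. They also leave open whether a shorter or longer chain carrying piperidin-1-yl would do so.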